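Extending a Reactive Arm in a Nucleotide Series

The source may hold more compounds than are shown below. What is called first, only, known or untested is meant among the compounds shown, and "the series" means these compounds.

Three compounds share one core and differ only in the arm attached through a nitrogen on an aromatic ring. Compound 1 `O=C(CI)NCCCNc1ncnc2c1ncn2[C@@H]1O[C@H](COP(=O)(O)OP(=O)(O)OP(=O)(O)O)[C@@H](O)[C@H]1O` carries the shortest arm; in an assay on isolated protein for inhibition of hexokinase-2 (Rattus norvegicus), with a stated time of 6 h, tested at 10 mM (a lower number here means less inhibition, a higher number more inhibition at the concentration tested (going by the name of the read-out)), compound 1 gives 0%. Compound 2 `O=C(CI)NCCCCNc1ncnc2c1ncn2[C@@H]1O[C@H](COP(=O)(O)OP(=O)(O)OP(=O)(O)O)[C@@H](O)[C@H]1O` has the arm extended by one saturated carbon, and in this assay compound 2 gives 0%. Compound 3 `O=C(CI)NCCC(=O)NCCCCCCNc1ncnc2c1ncn2[C@@H]1O[C@H](COP(=O)(O)OP(=O)(O)OP(=O)(O)O)[C@@H](O)[C@H]1O` has a longer arm still, with an additional amide inside it, and in this assay compound 3 gives 0%. Compound 2 therefore stands level with compound 1 and with compound 3 at the digits shown: no change at the digits printed from compound 1 to compound 2 (within the scatter), and no change at the digits printed from compound 2 to compound 3 (within the scatter).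

Compound 4 `O=C(CI)NCCCCCC(=O)NCCCCNc1ncnc2c1ncn2[C@@H]1O[C@H](COP(=O)(O)OP(=O)(O)OP(=O)(O)O)[C@@H](O)[C@H]1O` is built from compound 2 by a change in the same arm: 4-(((iodomethyl)carbonyl)amino)butyl in place of iodo on a saturated chain carbon bound to a carbonyl carbon. Both measured steps bear on this change, since each also lengthened the arm or inserted an amide into it, and neither moved the read-out beyond the scatter. The expected step is therefore no change at the digits printed from compound 2 to compound 4 (within the scatter), no change beyond the scatter. In this assay compound 4 is estimated to give 0%, with a range from 0% to 10%.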

Compound 4, a percentage reported as inhibition, at one concentration (the size of the read-out at that concentration, not a potency): 0%
Compound 4: middle estimate and measured number agree at the digits printed, and the stated range covers the measured number.
By their numbers in this assay, from the lowest: compounds 1, 2, 3 and 4 (each within the scatter of the next).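

Replacing iodo with 4-(((iodomethyl)carbonyl)amino)butyl on a saturated chain carbon bound to a carbonyl carbon gives no change at the digits printed from compound 2 to compound 4 (within the scatter) in this assay. Here, the rest of compound 2 stays as it was and all of the growth falls at this one carbon, where the entering group brings a hydrogen-bond donor, a hydrogen-bond acceptor and a double bond outside aromatic rings, and even a change of this size leaves the read-out where it was. No measurement shown here explains this flat result.

With all the compounds shown reading alike in this assay, the series gives no difference in inhibition to link to arm length or to the extra amide, so it cannot show which features of the arm matter, if any do. Going by these compounds, it remains open whether an amine or a carboxylic acid in place of the iodo at this carbon, or a longer chain between the carbonyl and the iodomethyl carbonyl amino end, would read any differently from compound 2.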